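Swapping the aryl substituent in a succinimide piperazine amide

The source may report more compounds than this note shows. Statements on the series, on what has been measured and on what is new or still open speak of the compounds shown alone.

Compound 1 `CC(C(=O)N1CCN(c2ccccc2C(F)(F)F)CC1)N1C(=O)CCC1=O` gives the highest of the three numbers available in a functional assay on the whole organism (strain Swiss) with Mus musculus as the target, in the maximal electroshock model, with a stated time of 2 h, at a dose of 300 mg/kg by the intraperitoneal route; a lower number here means a weaker effect, a higher number a stronger effect of the compound at the dose given: compound 1 reaches 75%. Compound 2 `CCC(C(=O)N1CCN(c2ccccc2C(F)(F)F)CC1)N1C(=O)CCC1=O` gives 0%, and compound 3 `CCC(C(=O)N1CCN(c2cccc(C)c2)CC1)N1C(=O)CCC1=O` gives 0%. Within the data shown here, the only step that differs in one place, a number 75 percentage points lower from compound 1 to compound 2 (beyond the scatter), concerns the chain carbon and not the aromatic ring. Among the measured compounds shown here, compound 4 `CC(C(=O)N1CCN(c2ccccc2Cl)CC1)N1C(=O)CCC1=O` differs from compound 1 by chloro in place of trifluoromethyl on an aromatic carbon, a change at the aromatic carbon that no measured pair isolates. Since the data give no guidance on this change, the expected step in this assay, a number 15 percentage points lower from compound 1 to compound 4 (beyond the scatter), is kept small but uncertain, and compound 4 is estimated at 60%, in the range 25% to 100%.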

Compound 4, a percentage reported as activity, at one dose (the size of the read-out at that dose, not a potency): 0%
Beside the measured number, compound 4's estimate is 60 percentage points above it, and the stated range ends above it.
By their numbers in this assay, from the lowest: compounds 2, 3 and 4 (each within the scatter of the next); then compound 1.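

Chloro in place of trifluoromethyl on an aromatic carbon gives a number 75 percentage points lower from compound 1 to compound 4 (beyond the scatter) in this assay. Among these compounds, the earlier step concerned only the chain carbon, so this is the first sign that the effect of compound 1 also depends on the group at this aromatic carbon. No available evidence explains the loss.

On these data alone, it remains open whether another group at this aromatic carbon, such as methoxy or a nitrile, would retain the effect of compound 1. As far as these compounds go, it is also open whether trifluoromethyl at another place on the ring would do so.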